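A few compounds are considered here, and "the series" means these few. Any claim that something is new, unique, unknown or untested is made for them only; others in the source may bear on it.

In an assay on HEK293 cells for positive allosteric modulation of metabotropic glutamate receptor 3 (Rattus norvegicus), read by thallium flux, with a stated time of 2.5 min (a higher number here means that more compound is needed for the effect, a lower number that less compound is needed), compound 1 `CCCC(=O)c1ccc(OCCCCOc2ccc(F)c(C(=O)O)c2)c(C)c1O` gives 438 nM. Compound 2 `COc1ccc(C(=O)O)cc1OCCCCOc1ccc(C(=O)C(C)C)c(O)c1C` gives 588 nM in this assay, and the two numbers sit within the scatter of each other, so neither stands apart. Compound 3 `Cc1c(OCCCCOc2ccc(F)c(C(=O)O)c2)ccc(C(=O)CC(C)(C)C)c1O` differs from compound 1 by tert-butyl in place of ethyl on a saturated chain carbon bound to a carbonyl carbon. Going by the values given here, no pair of measured compounds carries this change, so nothing here fixes its direction. The expected step of a 1.1-fold higher number from compound 1 to compound 3 (0.06 log units; within the scatter) is therefore no step beyond the scatter, held with wide uncertainty in either direction. Compound 3 is estimated at 500 nM, within a range from 150 nM to 1700 nM.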

Compound 3, half-maximal effective concentration: 258 nM
Compound 3: the middle estimate sits 1.9-fold (0.29 log units) above what was measured; measured number inside the range.
By their numbers in this assay, from the lowest: compounds 3, 1 and 2 (each within the scatter of the next, the first and the last beyond it).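

Exchanging ethyl for tert-butyl on a saturated chain carbon bound to a carbonyl carbon gives a 1.7-fold lower number from compound 1 to compound 3 (0.23 log units; within the scatter) in this assay. Going by these compounds alone, this is the first reading of any change at this position, and it shows that tert-butyl can stand in place of ethyl there without a step beyond the scatter. Nothing available explains this result. What the compounds shown leave open is whether a longer chain, a cyclohexyl ring or an amine at this place would give a step beyond the scatter. They also leave open whether the same exchange would read alike on another core.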